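A Sulfonyl Group Swap on a Shared Core

The source may hold more compounds than are shown below. What is called first, only, known or untested is meant among the compounds shown, and "the series" means these compounds.

Of the compounds shown here, three built on one shared core have been tested in a functional assay on HepG2 cells (Homo sapiens) for antiproliferative activity, with a stated time of 72 h; a higher number here means that more compound is needed for the effect, a lower number that less compound is needed. Compound 1 `COc1ccc(-c2[nH]c3cc(OC)cc(OC)c3c(=O)c2I)cc1` carries a hydrogen on its aromatic nitrogen; in this assay compound 1 gives only a limit of the assay, > 86200 nM. Compound 2 `COc1ccc(-c2c(I)c(=O)c3c(OC)cc(OC)cc3n2S(=O)(=O)c2ccc(OC)cc2)cc1` differs by a step that the two limits leave unreadable from compound 1 to compound 2; for compound 2 the result is again a limit, > 17300 nM. Compound 3 `COc1ccc(-c2cc(=O)c3c(OC)cc(OC)cc3n2S(=O)(=O)c2cccc([N+](=O)[O-])c2)cc1` likewise gives no number but a limit, > 39600 nM, so compound 3 stands at a limit, as do the other two values shown (the limit of > 17300 nM in this assay, at which 1 of the 3 values shown sits, (the limit of > 39600 nM in this assay, at which 1 of the 3 values shown sits), (the limit of > 86200 nM in this assay, at which 1 of the 3 values shown sits)).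

Compound 4 `COc1ccc(-c2cc(=O)c3c(OC)cc(OC)cc3n2S(=O)(=O)c2ccc(Br)s2)cc1` has not yet been measured in this assay. It differs from compound 3 in one place: 5-bromothiophen-2-yl in place of 3-nitrophenyl on a sulfonyl sulfur. For the measured compounds named here, no measured step speaks to this change; the single step that was measured, that from compound 1 to compound 2, is unreadable between two limits. Going by the values given here, with every value so far sitting at a limit, the most likely outcome is that compound 4 also reaches no number within the tested range.

Compound 4 is therefore expected to give roughly 40000 nM in this assay, within 10000 nM to 150000 nM, which means an expected step that the limit leaves unreadable from compound 3 to compound 4 from compound 3 to compound 4.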

Compound 4, half-maximal effective concentration: > 48200 nM
Compound 4: a limit, no number; the forecaster's own chance of this, stated with the estimate: 75%; at least 1.2-fold (0.08 log units) between middle value and limit.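

In this assay compound 4 gives only a limit of the assay, > 48200 nM, not a number. Compound 3 also stands at a limit, so no step can be read from compound 3 to compound 4. The compounds shown leave open how 5-bromothiophen-2-yl and 3-nitrophenyl on the sulfonyl sulfur truly compare, and whether any of these compounds reaches a measurable effect.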